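Aryl piperazine variation on the shared core: alpha-1B binding

This account rests on a few compounds, and the source may have more. Where it says the series, first, only, none or still open, it means among the compounds named here.

Measured so far:
compound 1 `COC(=O)C1=C(C)NC(=O)N(C(=O)NCCCN2CCN(c3ccccc3OC)CC2)C1c1ccc(F)c(F)c1` gives 18 nM in an assay on liver for binding affinity to Alpha-1B adrenergic receptor (Homo sapiens), using microsomes; a higher number here means a weaker inhibitor, a lower number a stronger inhibitor
compound 2 `COC(=O)C1=C(C)NC(=O)N(C(=O)NCCCN2CCN(c3cccc(Cl)c3)CC2)C1c1ccc(F)c(F)c1` gives 8.4 nM in this assay
compound 3 `COC(=O)C1=C(C)NC(=O)N(C(=O)NCCCN2CCN(c3ccc(OC)cc3C)CC2)C1c1ccc(F)c(F)c1` gives 510 nM in this assay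

Compound 1 holds the second highest of the three numbers: a 2.1-fold lower number from compound 1 to compound 2 (0.33 log units; beyond the scatter), while a 28-fold higher number from compound 1 to compound 3 (1.45 log units; beyond the scatter). Compound 4 `COC(=O)C1=C(C)NC(=O)N(C(=O)NCCCN2CCN(c3ccccc3Cl)CC2)C1c1ccc(F)c(F)c1` differs from compound 1 by chloro in place of methoxy on an aromatic carbon. The step of a 2.1-fold lower number from compound 1 to compound 2 (0.33 log units; beyond the scatter) also swaps methoxy for chloro, though the ring position differs, and it was modest. The step of a 28-fold higher number from compound 1 to compound 3 (1.45 log units; beyond the scatter) was large but changes two groups at once and does not bear directly on this swap. A small step in this assay is therefore expected for compound 4, in either direction, possibly none beyond the scatter. Compound 4 is estimated at 15 nM, within 5 nM to 50 nM, meaning an expected 1.2-fold lower number from compound 1 to compound 4 (0.08 log units; within the scatter).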

Compound 4, inhibition constant: 15 nM
Compound 4: middle estimate and measured number agree at the digits printed, within the range that was stated.
By their numbers in this assay, from the lowest: compounds 2, 4 and 1 (each within the scatter of the next, the first and the last beyond it); then compound 3.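

In this assay, chloro and methoxy on this aromatic carbon, ortho to a large group, cannot be told apart (a 1.2-fold lower number from compound 1 to compound 4 (0.08 log units; within the scatter)). Compound 4 also stays within the scatter of its 3-chlorophenyl counterpart (a 1.8-fold higher number from compound 2 to compound 4 (0.25 log units; within the scatter)), so here the chlorine position does not separate the two, while the 4-methoxy-2-methylphenyl compound stands well apart (a 34-fold lower number from compound 3 to compound 4 (1.53 log units; beyond the scatter)). No measurement available here accounts for these readings.

Compound 3 changes two places at once, so the 4-methoxy and 2-methyl contributions cannot be separated. As far as these compounds go, how a nitrile or a hydroxyl on this aromatic carbon would read remains open.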